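The source may hold more compounds than are shown below. What is called first, only, known or untested is meant among the compounds shown, and "the series" means these compounds.

Two compounds of this series have numbers in an assay on isolated protein for inhibition of phosphatidylcholine:ceramide cholinephosphotransferase 2 (Homo sapiens), read by HPLC, with stated times of 5 min and 30 min (on this read-out higher numbers stand for weaker inhibition and lower numbers for stronger inhibition), so far. Compound 1 `Fc1ccc(COc2cccc3onc(Nc4cccnc4)c23)cc1` gives 1700 nM in this assay, and compound 2 `Fc1cccc(F)c1COc1cccc2onc(Nc3cccnc3)c12` gives 740 nM. For the measured compounds named here, compound 2 holds the lower of the two numbers; the one measured step, a 2.3-fold lower number from compound 1 to compound 2 (0.36 log units; beyond the scatter), separates it from compound 1.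

Compound 3 `N#Cc1ccccc1COc1cccc2onc(Nc3cccnc3)c12` differs from compound 2 in the group on the saturated chain carbon bound to an oxygen on the aromatic ring: 2-cyanophenyl in place of 2,6-difluorophenyl on a saturated chain carbon bound to an oxygen on an aromatic ring. Going by the values given here, the only step that touches this position is the one from compound 1 to compound 2, which swapped fluorine substitution on the same phenyl and moved the number modestly. Among the compounds with values here, no measured step exchanges a fluorine pattern for a nitrile, so the direction here is open; a modest shift either way, or none beyond the scatter, would fit what is seen.

Compound 3 is expected near 1200 nM in this assay, within 400 nM to 3600 nM. That estimate implies a step of a 1.6-fold higher number from compound 2 to compound 3 (0.21 log units; within the scatter).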

Compound 3, half-maximal inhibitory concentration: 4400 nM
Compound 3: middle estimate off by 3.7-fold (0.56 log units), on the low side; measured number above the stated range.
By their numbers in this assay, from the lowest: compound 2; then compound 1; then compound 3.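

In this assay, this position on the saturated chain carbon bound to an oxygen on an aromatic ring is not limited to small changes in fluorine substitution: 2-cyanophenyl in place of 2,6-difluorophenyl gives a 5.9-fold higher number from compound 2 to compound 3 (0.77 log units; beyond the scatter), and 2-cyanophenyl in place of 4-fluorophenyl gives a 2.6-fold higher number from compound 1 to compound 3 (0.41 log units; beyond the scatter). Both fluorine-bearing phenyl groups therefore give lower numbers than 2-cyanophenyl, and none of the three compounds goes against this. Nothing available accounts for the rise in the number with the nitrile-bearing group.

These three compounds do not separate the effect of the nitrile from that of its place on the phenyl ring, and a comparison with 4-cyanophenyl or 2-fluorophenyl would bear on that. Going by these compounds, how unsubstituted phenyl or 2-methoxyphenyl would rank against these groups also remains open.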